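The compounds below may be only part of what the source reports. "The series", "measured", "known", "first", "only" and "open" are said of these compounds alone.

For the measured compounds named here, in an ADME assay on microsomes from liver (Rattus norvegicus) for metabolic stability, read by LC-MS, using NADPH, at 37 degrees C (a higher number here means that the compound lasts longer, a lower number that the compound disappears faster), compound 2 (`COc1cccc(Cl)c1-c1nc(CN2CCC(C(=O)NCCCN3C[C@H](C)C[C@H](C)C3)CC2)c(C)o1`) gives 0.055 h and stands lowest of the two compounds measured so far. Going by the values given here, compound 1 (`Cc1oc(-c2c(F)cccc2F)nc1CN1CCC(C(=O)NCCCN2C[C@H](C)C[C@H](C)C2)CC1`) gives 0.35 h and is the only other measured compound. Compound 3 (`COc1cccc(C)c1-c1nc(CN2CCC(C(=O)NCCCN3C[C@H](C)C[C@H](C)C3)CC2)c(C)o1`) has not been measured yet. It differs from compound 2 in one place (methyl in place of chloro on an aromatic carbon) with methyl in place of chloro on an aromatic carbon, so 2-chloro-6-methoxyphenyl becomes 2-methoxy-6-methylphenyl.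

Among the compounds with values here, only one measured step bears on this change. It is a 6.4-fold lower number from compound 1 to compound 2 (0.80 log units; beyond the scatter) and came with 2-chloro-6-methoxyphenyl in place of 2,6-difluorophenyl. Within the data shown here, that step brought in the chloro and the methoxy group together, so it does not separate the two, and no measured pair compares chloro with methyl directly. Compound 3 keeps the methoxy group, so the expectation stays close to compound 2 at 0.055 h and no step beyond the scatter is expected in this assay for now. The estimated step is a 1.1-fold lower number from compound 2 to compound 3 (0.04 log units; within the scatter) and stays within the usual scatter. The half-life expected for compound 3 is 0.05 h with a range from 0.025 h to 0.12 h around it.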

Compound 3, half-life: 0.0767 h
For compound 3 the middle estimate is 1.5-fold (0.19 log units) below the measured one; the measured number falls inside the stated range.
By their numbers in this assay, from the lowest: compounds 2 and 3 (each within the scatter of the next); then compound 1.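

In this assay, methyl in place of chloro at this position gives a 1.4-fold higher number from compound 2 to compound 3 (0.14 log units; within the scatter), so the two groups, one heavy atom each, cannot be told apart here when the methoxy group stays in place. The larger step from the 2,6-difluorophenyl compound remains with methyl as well, at a 4.6-fold lower number from compound 1 to compound 3 (0.66 log units; beyond the scatter), and this shows that the earlier 6.4-fold lower number from compound 1 to compound 2 (0.80 log units; beyond the scatter) does not depend on chloro being present. Nothing available gives a reason for these numbers.

Each step away from compound 1 changes both fluoro groups at once, and the compounds shown leave open how much of the shorter half-life goes with the methoxy group and how much with the replaced fluoro at the other side. From the compounds shown here alone, how an ethoxy group in place of the methoxy, or a nitrile or a hydroxyl group in place of the methyl, would read in this assay also remains open.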